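A few compounds are considered here, and "the series" means these few. Any claim that something is new, unique, unknown or untested is made for them only; others in the source may bear on it.

Measured in a functional assay on SK-BR-3 cells (Homo sapiens) for antiproliferative activity, read by MTT assay, with a stated time of 72 h; a higher number here means a weaker inhibitor, a lower number a stronger inhibitor:
Compound 1 `Cc1cc(NCCN(C)C)nc2ccc(NC(=O)c3ccc(Cl)c(Cl)c3)cc12`: 6670 nM
Compound 2 `Cc1cc(N(C)C)nc2ccc(NC(=O)c3ccc(Cl)c(Cl)c3)cc12`: > 50000 nM, which is a limit of the assay and not a number
Compound 3 `Cc1cc(NCCN2CCN(C)CC2)nc2ccc(NC(=O)c3ccc(Cl)c(Cl)c3)cc12`: 2690 nM

Of the three, compound 3 has the lowest number, 2690 nM. Compound 4 `Cc1cc(NCCN2CCCC2)nc2ccc(NC(=O)c3ccc(Cl)c(Cl)c3)cc12` has yet to be measured. It carries pyrrolidin-1-yl in place of 4-methylpiperazin-1-yl on a saturated chain carbon, two bonds along the chain from a nitrogen on an aromatic ring.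

Among the measured compounds shown here, the closest precedent is a swap at that same carbon, which gave a 2.5-fold lower number from compound 1 to compound 3 (0.39 log units; beyond the scatter), a modest change. The larger steps, an at least 7.4-fold higher number from compound 1 to compound 2 (0.87 log units; beyond the scatter) and an at least 18-fold lower number from compound 2 to compound 3 (1.26 log units; beyond the scatter), replace the entire group on the aromatic carbon, whereas compound 4 differs only at the end of the chain. Going by the modest size of a 2.5-fold lower number from compound 1 to compound 3 (0.39 log units; beyond the scatter), a small move towards a higher number in this assay is expected, possibly none beyond the scatter. The expected step is a 1.5-fold higher number from compound 3 to compound 4 (0.17 log units; within the scatter). The estimate for compound 4 is 4000 nM, with an expected range of 1500 nM to 10000 nM.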

Compound 4, half-maximal inhibitory concentration: 9530 nM
Estimate against measurement, compound 4: 2.4-fold (0.38 log units) below, within the range that was stated.
By their numbers in this assay, from the lowest: compound 3; then compounds 1 and 4 (each within the scatter of the next). At a limit, above all of these: compound 2.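

In this assay the swap of 4-methylpiperazin-1-yl for pyrrolidin-1-yl gives a 3.5-fold higher number from compound 3 to compound 4 (0.55 log units; beyond the scatter) and so shows that a ring at this chain carbon does not by itself bring the lower number of compound 3. Replacing dimethylamino with pyrrolidin-1-yl gives a 1.4-fold higher number from compound 1 to compound 4 (0.15 log units; within the scatter) and so does not separate these two groups at this place. The step of an at least 5.2-fold lower number from compound 2 to compound 4 (0.71 log units; beyond the scatter) shows that the chain form keeps its gain with pyrrolidin-1-yl, yet it is only a bound, because the value of compound 2 is a limit of the assay and not a number: the limit of > 50000 nM in this assay, at which 1 of the 4 values shown sits.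

Going by these compounds, whether morpholin-4-yl or piperidin-1-yl on the same chain carbon would fall nearer compound 3 or compound 4 stays open. So does the effect of a longer chain, such as 3-(4-methylpiperazin-1-yl)propyl in place of 2-(4-methylpiperazin-1-yl)ethyl.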